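A Second Chloro on the Core of Compound 3

The compounds below may be only part of what the source reports. "The series", "measured", "known", "first", "only" and "open" are said of these compounds alone.

Compound 1, `O=c1ccn(COCCO)c(=O)[nH]1`, gives in a functional assay (Oryctolagus cuniculus) for inhibition (on this read-out higher numbers stand for weaker inhibition and lower numbers for stronger inhibition), a limit of the assay, > 400 ug/mL.
Compound 2, `Nc1nc(=O)n(COCCO)cc1[N+](=O)[O-]`, gives in this assay likewise a limit, > 400 ug/mL.
Compound 3, `CC(=O)OCCOCn1cnc2c(Cl)ncnc21`, gives in this assay 60 ug/mL.

Among the compounds with values here, of the three measured compounds, only compound 3 yields a number in this assay; the other two sit at the limit of > 400 ug/mL in this assay, at which 2 of the 3 values shown sit, so compound 3 stands alone as the one compound with measured inhibition, and no comparison of size can be drawn between it and the others.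

Compound 4, `CC(=O)OCCOCn1cnc2c(Cl)nc(Cl)nc21`, has not yet been measured in this assay. It differs from compound 3 by chloro in place of hydrogen on an aromatic carbon. Within the data shown here, no step between two measured compounds is available to gauge what such a change does on this core, and nothing among the measured compounds speaks for a large effect in either direction. Compound 4 is therefore expected to stay close to compound 3, with at most a small shift toward stronger inhibition that may still lie within the scatter, an expected step of a 1.5-fold lower number from compound 3 to compound 4 (0.18 log units; within the scatter). The estimate for compound 4 in this assay is 40 ug/mL, expected between 12 ug/mL and 130 ug/mL.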

Compound 4, concentration for 50% inhibition: 10 ug/mL
Estimate against measurement, compound 4: 4.0-fold (0.60 log units) above; measured number below the stated range.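

In this assay, the change gives the first readable effect on this core: chloro in place of hydrogen on an aromatic carbon, between two ring nitrogen atoms, produces a 6.0-fold lower number from compound 3 to compound 4 (0.78 log units; beyond the scatter). This position therefore accepts a substituent, and here the added chloro, meta to the chloro group already present, goes with stronger inhibition rather than a loss of it. This single pair is still the only step that can be read, and any step to the other two compounds cannot be read, as they differ in more than one place and give only a limit: the limit of > 400 ug/mL in this assay, at which 2 of the 4 values shown sit.

What the compounds shown leave open is whether this gain belongs to chloro itself or would also appear with another group at the same position, such as bromo, methoxy or an amine. They also do not say whether the effect would hold if the acetate ester at the end of the side chain gave way to the free alcohol, or to a longer chain, on this same core.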